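Aryl exchange on the shared core: expectation for compound 4

A few compounds are considered here, and "the series" means these few. Any claim that something is new, unique, unknown or untested is made for them only; others in the source may bear on it.

Measured so far in a functional assay on A549 cells (Homo sapiens) for inhibition, read by MTT assay, with a stated time of 48 h; on this read-out higher numbers stand for weaker inhibition and lower numbers for stronger inhibition:
- compound 1, `Fc1ccc(/C=N/Nc2nc(-c3cc(C(F)(F)F)cc(C(F)(F)F)c3)cs2)cc1F`: 6230 nM
- compound 2, `COc1cc(/C=N/Nc2nc(-c3ccc(C(F)(F)F)cc3)cs2)c(Br)c(Br)c1OC`: 17600 nM
- compound 3, `Fc1ccc(/C=N/Nc2nc(-c3ccc(F)c(F)c3)cs2)cc1F`: 8490 nM

Compound 2 carries the highest number of the three in this assay, and both gaps to it are beyond the scatter: compound 3 sits nearer, compound 1 furthest away. On these numbers compound 2 is the weakest inhibitor of the set.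

Compound 4, `COc1cc(/C=N/Nc2nc(-c3cccc(Br)c3)cs2)c(Br)c(Br)c1OC`, keeps the dimethoxy-dibromo side of compound 2 and changes only the aryl on the shared core: 3-bromophenyl in place of 4-(trifluoromethyl)phenyl on an aromatic carbon. Within the data shown here, no measured pair shows this aryl change on its own, so the direction of the step is not known from the series. The three measured compounds all lie in the same weak range, and the change leaves the donor and acceptor count untouched. A step of about the size of the scatter, in either direction, is expected, with the result staying in the weak range.

Compound 4 is estimated at 14000 nM, range 6000 nM to 35000 nM, which means an expected step of a 1.3-fold lower number from compound 2 to compound 4 (0.10 log units; within the scatter).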

Compound 4, half-maximal inhibitory concentration: 37000 nM
For compound 4 the middle estimate is 2.6-fold (0.42 log units) below the measured one; the measured number lies above the stated range.
By their numbers in this assay, from the lowest: compounds 1 and 3 (each within the scatter of the next); then compound 2; then compound 4.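

In this assay, the aryl next to the ring nitrogen of the shared core is not a silent position: with the dimethoxy-dibromo side held fixed, 3-bromophenyl in place of 4-(trifluoromethyl)phenyl gives a 2.1-fold higher number from compound 2 to compound 4 (0.32 log units; beyond the scatter), a modest loss of inhibition. Among these compounds, this is the only single-place comparison so far, so the direction is established for this one side of the molecule alone. Nothing measured on these compounds speaks to why the number rises.

The compounds shown do not separate the exchange of trifluoromethyl for bromine from the shift in where the substituent sits on the phenyl ring. Also open, on these data alone, are how a phenyl bearing an amine or a carboxylic acid would read here, and whether the same exchange carries over to the side found in compound 1 and compound 3.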